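A few compounds are considered here, and "the series" means these few. Any claim that something is new, unique, unknown or untested is made for them only; others in the source may bear on it.

Measured so far:

- compound 1, `O=S(=O)(c1cccc(Cl)c1)c1cn(C2CCCNC2)c2ncccc12`: in a functional assay on HeLa cells for agonist activity at 5-hydroxytryptamine receptor 6 (Homo sapiens), read by cAMP accumulation and immunoassay (on this read-out higher numbers stand for larger maximal responses and lower numbers for smaller maximal responses), compound 1 reaches 49%
- compound 2, `O=S(=O)(c1cccc(Br)c1)c1cn(C2CCCNC2)c2ncccc12`: in this assay compound 2 reaches 49%

Going by the values given here, compound 2 stands level with compound 1 on these numbers: the only measured step, no change at the digits printed from compound 1 to compound 2 (within the scatter), exchanges one group of a single heavy atom for another at the same place and leaves the maximal response where it was.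

The next compound, compound 3, `O=S(=O)(c1cccc(F)c1)c1cn(C2CCCNC2)c2ncccc12`, is reached from compound 2 by a change of the same kind: fluoro in place of bromo on an aromatic carbon. Among the compounds with values here, the one step that bears on it is no change at the digits printed from compound 1 to compound 2 (within the scatter), which was no change within the scatter for a swap of this sort at this very position. Nothing else among the measured compounds speaks to the size of the fluoro group in particular, so the expectation for this assay rests on that single comparison and is a step of no size beyond the scatter, in no particular direction.

Compound 3 is therefore expected to come out at 49%, within a range from 37% to 61%, which means an estimated step of no change at the digits printed from compound 2 to compound 3 (within the scatter).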

Compound 3, largest response reached (Emax), in percent of the reference or control that the assay uses: 84%
The estimate for compound 3 lay 35 percentage points below the measured number; measured number outside the range, above it.
By their numbers in this assay, from the lowest: compounds 1 and 2 (each within the scatter of the next); then compound 3.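

In this assay the three halogens at this place do not behave alike: fluoro gives a number 35 percentage points higher from compound 2 to compound 3 (beyond the scatter) and also a number 35 percentage points higher from compound 1 to compound 3 (beyond the scatter) in the same comparison with chloro. The earlier pair, compound 1 and compound 2, suggested that one halogen could stand in for another here without consequence, but the new compound shows that this holds only for chloro and bromo, while a swap of one single heavy atom for another on the same aromatic carbon can also move the maximal response by a large step. This change from 3-bromophenyl to 3-fluorophenyl adds no ring, hydrogen-bond donor, hydrogen-bond acceptor or net charge, and no measurement shown here bears on what lies behind the step.

Still open, going by these compounds, is how a hydrogen, a methyl, a methoxy or a trifluoromethyl group would fare at this same carbon, so it cannot yet be said whether the larger response is particular to fluoro. Also open, on these data alone, is whether the same exchange of bromo for fluoro would give a step of similar size on a core carrying a different amine.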